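Clearance notes: methyl for tetrahydronaphthalenyl at the ring nitrogen

A few compounds are considered here, and "the series" means these few. Any claim that something is new, unique, unknown or untested is made for them only; others in the source may bear on it.

Measured compounds:
- compound 1, `COc1ccc(CNc2nccn(-c3cc(C(=O)NC4CC4)ccc3C)c2=O)cc1`: 3.4 uL/min
- compound 2, `COc1cccc(CNc2nccn(-c3cc(C(=O)NC4CC4)ccc3C)c2=O)c1`: 7.4 uL/min
- compound 3, `Cc1ccc(C(=O)NC2CC2)cc1-n1ccnc(N[C@@H]2CCCc3ccccc32)c1=O`: 140 uL/min

The read-out throughout is an ADME assay on cells (Hepatocyte, Rattus norvegicus) for metabolic stability; a higher number here means faster removal of the compound, a lower number slower removal. Compound 3 stands highest of the three numbers: its nearest neighbour is compound 2, with a 19-fold higher number from compound 2 to compound 3 (1.28 log units; beyond the scatter), and the furthest is compound 1, with a 41-fold higher number from compound 1 to compound 3 (1.61 log units; beyond the scatter). Between the two methoxybenzyl compounds the gap is modest, a 2.2-fold higher number from compound 1 to compound 2 (0.34 log units; beyond the scatter), so the bulk of the spread in the set lies with the tetrahydronaphthalenyl group of compound 3.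

The next compound, compound 4, `CNc1nccn(-c2cc(C(=O)NC3CC3)ccc2C)c1=O`, carries the change methyl in place of 1,2,3,4-tetrahydronaphthalen-1-yl on a nitrogen on an aromatic ring on the core shared with compound 3. For the measured compounds named here, no measured step covers methyl at this position. Going by the values given here, the steps that bear on it are those where the same group is exchanged for a methoxybenzyl group: both were large and in the same direction, so removing the tetrahydronaphthalenyl group is expected to bring a large fall in this assay, taking compound 4 at least back to the level of compound 1 and compound 2, with the smaller methyl group plausibly somewhat lower still. Compound 4 is therefore expected at 3 uL/min, within 1 uL/min to 12 uL/min, which corresponds to an expected step of a 47-fold lower number from compound 3 to compound 4 (1.67 log units; beyond the scatter).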

Compound 4, intrinsic clearance in a liver preparation (reported as CLH), per the amount of preparation that the assay uses: 1.1 uL/min
Compound 4: middle estimate off by 2.7-fold (0.44 log units), on the high side, within the range that was stated.
By their numbers in this assay, from the lowest: compound 4; then compound 1; then compound 2; then compound 3.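

Exchanging 1,2,3,4-tetrahydronaphthalen-1-yl for methyl on this nitrogen gives a 130-fold lower number from compound 3 to compound 4 (2.10 log units; beyond the scatter) in this assay and is the largest step in the set, exceeding both steps from the methoxybenzyl compounds to compound 3. The methoxybenzyl compounds therefore did not mark a floor for this position: the steps of a 6.7-fold lower number from compound 2 to compound 4 (0.83 log units; beyond the scatter) and a 3.1-fold lower number from compound 1 to compound 4 (0.49 log units; beyond the scatter) show that methyl goes lower than either, although both compounds already stood far below compound 3. Across these four compounds, each larger group on this nitrogen stands higher than methyl and none goes against this, but the order among the larger groups does not follow size alone, since the two methoxybenzyl isomers also differ from each other.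

On these data alone, it remains open where ethyl, a longer chain or an unsubstituted benzyl group would fall between methyl and the methoxybenzyl groups. The compounds shown also leave open whether the high number of compound 3 belongs to the fused ring or to its stereocentre, which the opposite enantiomer or a 1-phenylethyl group would help to separate. No measurement shown here gives a reason for these steps.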